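This account rests on a few compounds, and the source may have more. Where it says the series, first, only, none or still open, it means among the compounds named here.

Within the data shown here, compound 1 `CCCCn1cnc2[nH]c(=O)[nH]c(=O)c21` gives 27000 nM in an assay on cell membranes from brain for binding affinity to adenosine receptor A1 (Rattus norvegicus), read by radioligand binding (a lower number here means a stronger inhibitor, a higher number a weaker inhibitor), the highest of the two numbers known here; compound 2 `C=CCn1c(=O)[nH]c2[nH]cnc2c1=O` gives 9200 nM in this assay, a gap beyond the scatter, although the two differ in more than one place and no single step connects them. Compound 3 `CCCn1cnc2[nH]c(=O)[nH]c(=O)c21` differs from compound 1 only by hydrogen in place of methyl on a saturated chain carbon, three bonds along the chain from an aromatic nitrogen, so that butyl becomes propyl. Among the measured compounds shown here, with no measured step of this kind at hand, the change is expected to be small, within the scatter, for compound 3 in this assay, a 1.1-fold lower number from compound 1 to compound 3 (0.03 log units; within the scatter), giving an estimate of 25000 nM with a range from 10000 nM to 60000 nM.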

Compound 3, inhibition constant: 18000 nM
Compound 3: the middle estimate sits 1.4-fold (0.14 log units) above what was measured; low and high end bracket the measured number.
By their numbers in this assay, from the lowest: compounds 2, 3 and 1 (each within the scatter of the next, the first and the last beyond it).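

Among these compounds, this is the first measured step at this position: on a saturated chain carbon, three bonds along the chain from an aromatic nitrogen, butyl becoming propyl gives a 1.5-fold lower number from compound 1 to compound 3 (0.18 log units; within the scatter) in this assay and so leaves the number within the scatter. Nothing available explains this result. As far as these compounds go, whether ethyl, methyl or a longer chain such as pentyl at this nitrogen would give a step beyond the scatter remains open. So does the effect of placing an amine or a carboxylic acid at the end of the chain.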